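Chloro to methoxy on two cores: lipophilicity compared

The source may report more compounds than this note shows. Statements on the series, on what has been measured and on what is new or still open speak of the compounds shown alone.

Measured compounds:
compound 1 `COc1ccccc1-c1nc(N)nc(N)n1` with 0.58
compound 2 `Cc1c(N(C)C)c(=O)n(C)c(=O)n1-c1ccc(Cl)cc1` with 2.32
compound 3 `Nc1nc(N)nc(-c2ccccc2Cl)n1` with 1.19

Of the compounds shown here, three have been measured in a physicochemical assay for lipophilicity; on this read-out higher numbers stand for higher lipophilicity and lower numbers for lower lipophilicity. Compound 2 stands highest of the three; compound 3 is nearest to it and compound 1 furthest, both gaps beyond the scatter. Compound 3 and compound 1 differ in one place: methoxy in place of chloro on an aromatic carbon The step is a number 0.61 log units lower from compound 3 to compound 1 (beyond the scatter).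

The unmeasured compound 4 `COc1ccc(-n2c(C)c(N(C)C)c(=O)n(C)c2=O)cc1` relates to compound 2 in the same way: methoxy in place of chloro on an aromatic carbon The difference between the two cores of compound 2 and compound 3 is not broken down here. The surroundings of the change also differ: in the first pair the place is ortho to a group of 8 heavy atoms, in the second it is para to a large group, so this is the same kind of change rather than the same change.

The expectation for compound 4 rests on the measured step from compound 3 to compound 1, and the estimated step of a number 0.61 log units lower from compound 2 to compound 4 (beyond the scatter) is taken to be of similar size in this assay. Compound 4 is thus estimated at 1.71, with a range from 1.3 to 2.1.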

Compound 4, partition coefficient: 1.96
Compound 4: middle estimate off by 0.25 log units, on the low side; measured number inside the range.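

In this assay, methoxy in place of chloro on an aromatic carbon gives a number 0.36 log units lower from compound 2 to compound 4 (beyond the scatter) on the second core, and this runs in the same direction as a number 0.61 log units lower from compound 3 to compound 1 (beyond the scatter) on the first, with both steps modest. This shows that the direction of the change carried over between these two cores, but two pairs do not establish a fixed size for the step or a rule for the whole series, and the place of the change is not the same in the two pairs. Nothing in the available data bears on why the step takes the size it does.

The compounds shown leave open how an ethoxy group or an amine in place of chloro would read on either core, and whether a carboxylic acid there would move the number the same way. They also leave open whether methoxy in place of chloro keeps this direction on a third core.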